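From Methoxy to Ethoxy: One Small Step

A few compounds are considered here, and "the series" means these few. Any claim that something is new, unique, unknown or untested is made for them only; others in the source may bear on it.

Compound 1 (`COc1ccc(Nc2cc(NC(=O)c3ccccc3)ncn2)cc1`) is the starting point here. Among the measured compounds shown here, in a functional assay on HCC827 cells (Homo sapiens) for antiproliferative activity, read by MTT assay, with a stated time of 72 h (a lower number here means a stronger inhibitor, a higher number a weaker inhibitor), compound 1 gives 5350 nM, the only true number available so far. Its companion, compound 2 (`O=C(Nc1cc(Nc2ccc(Cl)cc2)ncn1)c1ccc(F)cc1`), is recorded in this assay as > 30000 nM, which is a limit of the assay and not a number.

Next comes compound 3 (`CCOc1ccc(Nc2cc(NC(=O)c3ccccc3)ncn2)cc1`), which has not yet been measured. It differs from compound 1 by a single small change, methoxy to ethoxy: methyl in place of hydrogen on a saturated chain carbon bound to an oxygen on an aromatic ring. For the measured compounds named here, no measured pair here differs in only one place, so the data give no direct guide to what such a change does. The expectation therefore starts from compound 1 at 5350 nM and assumes no shift beyond the usual scatter of repeated measurements, in either direction. The step expected is a 1.1-fold lower number from compound 1 to compound 3 (0.03 log units; within the scatter). For compound 3 the estimated value is 5000 nM, with an expected range from 1800 nM to 15000 nM.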

Compound 3, half-maximal inhibitory concentration: 7000 nM
Beside the measured number, compound 3's estimate is 1.4-fold (0.15 log units) below it, within the range that was stated.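

Going from methoxy to ethoxy, on a saturated chain carbon bound to an oxygen on an aromatic ring, gives the first readable step between two compounds that differ in one place: a 1.3-fold higher number from compound 1 to compound 3 (0.12 log units; within the scatter). In this assay, then, the added methyl leaves no difference that can be told apart from the ordinary spread of repeated measurements, so this place accepts one more carbon with no visible effect on the read-out. Compound 2 alone sits at a limit of the assay, whereas compound 1 and compound 3 both give true numbers, which is what allows this pair to be compared directly: the limit of > 30000 nM in this assay, at which 1 of the 3 values shown sits.

As far as these compounds go, one added methyl is a very small probe, so it remains open whether this place would stay as undemanding with a longer chain such as propoxy, or with an amine or a carboxylic acid at the end of the chain. A single pair also cannot show whether the same step would hold if another part of the core of compound 1 were different.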